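Three inactive amides and an acetylphenyl analogue

A few compounds are considered here, and "the series" means these few. Any claim that something is new, unique, unknown or untested is made for them only; others in the source may bear on it.

Compound 3 `CCOC(=O)CCCCCOc1cccc(CN(C(=O)c2ccc(-c3cccnc3)cc2)C(C)C)c1` is one of three measured members of a series that share one core and differ only in the aryl group attached to the benzamide ring. In an ADME assay on Raji cells (Homo sapiens) for cytotoxicity, read by CellTiter-Glo and resazurin assay, with a stated time of 72 h (a lower number here means that less compound is needed, a higher number that more compound is needed for the effect), compound 3 gives > 26000 nM, which is a limit of the assay and not a number. Compound 1 `CCOC(=O)CCCCCOc1cccc(CN(C(=O)c2ccc(-c3ccncc3)cc2)C(C)C)c1` likewise gives > 26000 nM, again a limit. Compound 2 `CCOC(=O)CCCCCOc1cccc(CN(C(=O)c2ccc(-c3cccc(-c4ccccc4)c3)cc2)C(C)C)c1` gives > 26000 nM, also a limit. Because all three values sit at the limit of > 26000 nM in this assay, at which 3 of the 3 values shown sit, the steps between them cannot be read: a step that the two limits leave unreadable from compound 1 to compound 2, a step that the two limits leave unreadable from compound 1 to compound 3 and a step that the two limits leave unreadable from compound 2 to compound 3. Compound 3 therefore stands level with the other two at the limit, with no ordering possible.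

Compound 4 `CCOC(=O)CCCCCOc1cccc(CN(C(=O)c2ccc(-c3cccc(C(C)=O)c3)cc2)C(C)C)c1` is not yet measured. It differs from compound 3 in one place: 3-acetylphenyl in place of pyridin-3-yl on an aromatic carbon. All three measured steps bear on a change at this position, and none of them could be resolved, so no direction can be drawn from them. The expected step from compound 3 to compound 4 in this assay is accordingly a step that the limit leaves unreadable from compound 3 to compound 4, meaning no readable change. For compound 4 the estimated value in this assay is 40000 nM, with a range from 15000 nM to 150000 nM, and the measurement is expected most likely to return only a limit again.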

Compound 4, half-maximal effective concentration: > 26000 nM
Compound 4 gave a limit, no number (the forecaster's own chance of this, stated with the estimate: 75%); the middle value does not contradict the limit.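

In this assay compound 4 gives > 26000 nM as a limit of the assay and not a number. No step from compound 1, compound 2 or compound 3 to compound 4 can be read, because every value sits at the same limit: the limit of > 26000 nM in this assay, at which 4 of the 4 values shown sit.

Left open is how the four compounds would rank in this assay and whether any aryl group on the shared core reaches a readable value.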